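Adding one fluoro to compound 3

A few compounds are considered here, and "the series" means these few. Any claim that something is new, unique, unknown or untested is made for them only; others in the source may bear on it.

Measured in a functional assay on MCF7 cells (Homo sapiens) for antiproliferative activity, read by MTT assay, with a stated time of 48 h; a higher number here means a weaker inhibitor, a lower number a stronger inhibitor:
compound 1 `COc1ccc(/C=C/C(=O)Nc2nnc(-c3ccc(C)cc3)s2)cc1`: 0.35 ug/mL
compound 2 `COc1ccc(-c2nnc(NC(=O)/C=C/c3ccc(F)cc3)s2)cc1`: 0.85 ug/mL
compound 3 `Cc1ccc(-c2nnc(NC(=O)/C=C/c3ccccc3)s2)cc1`: 1.19 ug/mL

Compound 3 gives 1.19 ug/mL, which lies within the scatter of compound 2, while the number for compound 1 is clearly lower. Compound 4 `Cc1ccc(-c2nnc(NC(=O)/C=C/c3ccc(F)cc3)s2)cc1` is compound 3 with a single change: fluoro in place of hydrogen on an aromatic carbon.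

For the measured compounds named here, one measured step touches that same carbon: a 3.4-fold higher number from compound 1 to compound 3 (0.53 log units; beyond the scatter), hydrogen in place of methoxy on an aromatic carbon. It shows that the number can move with this place, but it concerns methoxy, not fluoro. Going by the values given here, compound 2 carries the fluoro, yet it differs from compound 3 at a second place as well, so no measured step isolates the fluoro. On this thin evidence, only a small step toward a lower number is expected in this assay, probably within the scatter. The estimated change is a 1.4-fold lower number from compound 3 to compound 4 (0.15 log units; within the scatter). For compound 4 the expected value is 0.85 ug/mL, with an estimated range of 0.35 ug/mL to 1.9 ug/mL.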

Compound 4, half-maximal inhibitory concentration: 1.27 ug/mL
The estimate for compound 4 lay 1.5-fold (0.17 log units) below the measured number; the range from low to high includes it.
By their numbers in this assay, from the lowest: compound 1; then compounds 2, 3 and 4 (each within the scatter of the next).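

In this assay, for the compounds shown here, fluoro in place of hydrogen gives a 1.1-fold higher number from compound 3 to compound 4 (0.03 log units; within the scatter) and so this carbon, whose number moved with methoxy, shows no response to fluoro in the one step that isolates it. Fluoro in place of methoxy gives a 3.6-fold higher number from compound 1 to compound 4 (0.56 log units; beyond the scatter) and hydrogen in place of methoxy gives a 3.4-fold higher number from compound 1 to compound 3 (0.53 log units; beyond the scatter) and so, of these three groups, methoxy alone stands apart at this carbon. At the second place, methyl in place of methoxy on an aromatic carbon gives a 1.5-fold higher number from compound 2 to compound 4 (0.17 log units; within the scatter) and so, with fluoro present, that swap stays within the scatter.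

As far as these compounds go, whether an amine or a hydroxyl at this carbon would read like methoxy or like hydrogen stays open. No evidence given here bears on this result.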